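This account rests on a few compounds, and the source may have more. Where it says the series, first, only, none or still open, it means among the compounds named here.

Measured so far: compound 1 `CC(CSc1ccc(F)cc1)C(=O)Nc1ccc([N+](=O)[O-])c(C(F)(F)F)c1` with 27200 nM; compound 2 `CC(CSc1ccc(C(F)(F)F)cc1)(Sc1ccc(C(F)(F)F)cc1)C(=O)Nc1ccc(C#N)c(C(F)(F)F)c1` with 1680 nM; compound 3 `CC(CS(=O)(=O)c1cc(C(F)(F)F)cc(C(F)(F)F)c1)C(=O)Nc1ccc(C#N)c(C(F)(F)F)c1` with 6160 nM.

These three compounds were tested in a functional assay on LNCaP cells (Homo sapiens) for antiproliferative activity, read by MTT assay, with a stated time of 96 h; on this read-out higher numbers stand for weaker inhibition and lower numbers for stronger inhibition. Compound 3 holds the second highest of the three numbers. Its nearest neighbour is compound 2, whose number lies a good way lower, beyond the scatter; the furthest is compound 1, whose number lies higher by a somewhat larger margin, again beyond the scatter. Compound 3 thus sits between the two, closer in log terms to compound 2.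

Compound 4 `CC(CS(=O)(=O)c1cc(C(F)(F)F)cc(C(F)(F)F)c1)C(=O)Nc1ccc([N+](=O)[O-])c(C(F)(F)F)c1` has not yet been measured in this assay. It differs from compound 3 in one place: nitro in place of cyano on an aromatic carbon. For the measured compounds named here, no pair of measured compounds isolates this exchange, so its effect can only be guessed. Going by the values given here, the only nitro-bearing compound, compound 1, gives 27200 nM, the highest number of the set, but it also differs from compound 3 in the sulfur-linked part, so that comparison is not clean. On this basis the step from compound 3 to compound 4 is expected to be small, at most a mild rise in the number, a 1.4-fold higher number from compound 3 to compound 4 (0.14 log units; within the scatter), and likely within or near the scatter. Compound 4 is therefore estimated at 8500 nM, with a range from 3000 nM to 25000 nM.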

Compound 4, half-maximal inhibitory concentration: 12200 nM
For compound 4 the middle estimate is 1.4-fold (0.16 log units) below the measured one; the range from low to high includes it.
By their numbers in this assay, from the lowest: compound 2; then compounds 3 and 4 (each within the scatter of the next); then compound 1.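

In this assay, nitro in place of cyano on an aromatic carbon, at the place ortho to a trifluoromethyl group and para to a large group, gives a 2.0-fold higher number from compound 3 to compound 4 (0.30 log units; within the scatter). For the compounds shown here, this is the first direct reading of the exchange in the set: with the rest of the structure held constant, the two groups cannot be told apart at this position, even though the entering group brings one more heavy atom and one more hydrogen-bond acceptor than the group that leaves. Nothing available here bears on why the exchange reads this way.

As far as these compounds go, the pair speaks for only one sulfur-linked part, so it remains open whether the same exchange would read alike with the sulfur-linked parts of compound 1 or compound 2, which have no matched partner here. From the compounds shown here alone, it also remains open how an amine, a carboxylic acid or a simple hydrogen at this aromatic carbon would compare with nitro and cyano, since only these two groups have been seen at this position on the shared core.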